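A few compounds are considered here, and "the series" means these few. Any claim that something is new, unique, unknown or untested is made for them only; others in the source may bear on it.

Measured in a functional assay on Huh-7 cells (Homo sapiens) for inhibition, read by MTT assay, with a stated time of 48 h; a lower number here means a stronger inhibitor, a higher number a weaker inhibitor:
Compound 1 `COc1ccc2c(=O)c(/C=C/C(=O)Nc3ccccc3)coc2c1`: 9050 nM.
Compound 2 `Cc1ccc(CNC(=O)/C=C/c2coc3cc(O)ccc3c2=O)cc1`: > 100000 nM, which is a limit of the assay and not a number.

Within the data shown here, compound 1 holds the only numerical value so far; the other entry stands at the limit of > 100000 nM in this assay, at which 1 of the 2 values shown sits. Among the measured compounds shown here, no pair of measured compounds differs in a single place, so the size of the move to compound 3 `COc1ccc2c(=O)c(/C=C/C(=O)NCc3ccc(F)cc3F)coc2c1` cannot be read off from a measured step. The change from compound 1 to compound 3 is 2,4-difluorobenzyl in place of phenyl on an amide-type nitrogen. Compound 2 also carries an amide nitrogen bearing a benzyl-type group, and in this assay it gives only a limit, but it differs from compound 1 in more than one place, so nothing firmer follows from it. A step toward weaker inhibition, beyond the scatter, is expected: a 2.8-fold higher number from compound 1 to compound 3 (0.44 log units; beyond the scatter). Compound 3 is estimated at 25000 nM, within a range from 6000 nM to 100000 nM.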

Compound 3, half-maximal inhibitory concentration: > 100000 nM
Compound 3 was reported as a limit; the forecaster's own chance of this, stated with the estimate: 30%; at least 4.0-fold (0.60 log units) between middle value and limit.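

Among these compounds, on the amide-type nitrogen, 2,4-difluorobenzyl in place of phenyl gives an at least 11-fold higher number from compound 1 to compound 3 (1.04 log units; beyond the scatter), the first step that can be read between two compounds differing in one place. In this assay, going by these compounds, compound 3 gives > 100000 nM, which is a limit of the assay and not a number, so the step sets only a lower bound on the loss and its full size stays unknown. Phenyl on this nitrogen is so far the only group with a numerical value, and of the compounds shown only compound 1 gives a number: the limit of > 100000 nM in this assay, at which 2 of the 3 values shown sit.

The change brings in the benzyl carbon and the two fluorines together, and the compounds shown do not separate them. Plain benzyl or a fluorophenyl on the same nitrogen would tell these two parts apart, and whether any group here improves on phenyl remains open.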